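The compounds below may be only part of what the source reports. "The series", "measured", "known", "first", "only" and "open" are said of these compounds alone.

Values in a functional assay on HepG2 cells (Homo sapiens) for inhibition, read by MTT assay, with a stated time of 72 h; a higher number here means a weaker inhibitor, a lower number a stronger inhibitor:
- compound 1 `CC(C)(C)n1cc2c(n1)C(=O)CC1(CCN(C(=O)c3cc(-c4ccccc4)nc4ccccc34)CC1)O2` gives 2110 nM
- compound 2 `CC(C)(C)n1cc2c(n1)C(=O)CC1(CCN(C(=O)c3cc(-c4ccc(F)cc4)nc4ccccc34)CC1)O2` gives 2930 nM
- compound 3 `COc1ccc(-c2cc(C(=O)N3CCC4(CC3)CC(=O)c3nn(C(C)(C)C)cc3O4)c3ccccc3n2)cc1OC` gives 1560 nM

Compound 3 is not separated from the other two compounds: the data show a 1.4-fold lower number from compound 1 to compound 3 (0.13 log units; within the scatter) and a 1.9-fold lower number from compound 2 to compound 3 (0.27 log units; within the scatter), and both steps lie within the scatter. The next compound, compound 4 `CN(C)c1ccc(-c2cc(C(=O)N3CCC4(CC3)CC(=O)c3nn(C(C)(C)C)cc3O4)c3ccccc3n2)cc1`, carries 4-(dimethylamino)phenyl in place of 3,4-dimethoxyphenyl on an aromatic carbon. The three measured steps all change the phenyl group at this same place. The third of them is a 1.4-fold higher number from compound 1 to compound 2 (0.14 log units; within the scatter), also within the scatter. Among the compounds with values here, none of the three compounds carries a dimethylamino group, so the data offer no direct precedent for this change. With all three steps this small, no step beyond the scatter is expected in this assay, and no direction can be claimed. The expected step is a 1.2-fold higher number from compound 3 to compound 4 (0.06 log units; within the scatter). For compound 4 the estimated value is 1800 nM, with an expected range from 800 nM to 4000 nM.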

Compound 4, half-maximal inhibitory concentration: 1730 nM
Compound 4: the middle estimate sits 1.0-fold (0.02 log units) above what was measured; measured number inside the range.
By their numbers in this assay, from the lowest: compounds 3, 4, 1 and 2 (each within the scatter of the next).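

In this assay the data show a 1.1-fold higher number from compound 3 to compound 4 (0.04 log units; within the scatter) and a 1.7-fold lower number from compound 2 to compound 4 (0.23 log units; within the scatter) and a 1.2-fold lower number from compound 1 to compound 4 (0.09 log units; within the scatter) for 4-(dimethylamino)phenyl on the aromatic carbon next to the ring nitrogen. This position now accepts a nitrogen substituent on the phenyl group, as well as hydrogen, fluoro and two methoxy groups, and all four compounds remain inside the scatter of one another, so no substituent on this phenyl group has yet separated from the others. Nothing available explains this insensitivity.

Still open, going by these compounds, is whether a carboxylic acid or a primary amine on this phenyl group would give a step beyond the scatter. Also open, on these data alone, is whether replacing the whole phenyl group with a morpholine ring would do so.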